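Fluoro to methyl on the benzyl group of compound 3

The source may report more compounds than this note shows. Statements on the series, on what has been measured and on what is new or still open speak of the compounds shown alone.

Compound 3 `O=C1/C(=N\NC(=S)Nc2ccc(Cl)cc2)c2cc(Br)ccc2N1Cc1ccc(F)cc1` gives 48000 nM in a functional assay on MOLT-4 cells (Homo sapiens), with a stated time of 72 h (a higher number here means a weaker inhibitor, a lower number a stronger inhibitor), the highest of the three numbers shown. Its nearest neighbour is compound 1 `O=C1Nc2ccc(Br)cc2/C1=N/NC(=S)Nc1ccc(Cl)cc1`, at 29000 nM; the step of a 1.7-fold higher number from compound 1 to compound 3 (0.22 log units; within the scatter) lies within the scatter. Compound 2 `Cc1ccc(CN2C(=O)/C(=N\NC(=S)Nc3ccc(Cl)cc3)c3cc(Cl)ccc32)cc1` gives 5800 nM in this assay, well beyond the scatter from compound 3. The change to compound 4 `Cc1ccc(CN2C(=O)/C(=N\NC(=S)Nc3ccc(Cl)cc3)c3cc(Br)ccc32)cc1` is methyl in place of fluoro on an aromatic carbon. Going by the values given here, no measured step covers this exchange alone; compound 2 carries the 4-methylbenzyl group but also chloro in place of bromo on the core, so only its value speaks here. A moderate move toward compound 2 is expected, with wide uncertainty. For compound 4 the estimate is 15000 nM, range 5000 nM to 45000 nM, a step of a 3.2-fold lower number from compound 3 to compound 4 (0.51 log units; beyond the scatter) expected.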

Compound 4, half-maximal inhibitory concentration: 74000 nM
For compound 4 the middle estimate is 4.9-fold (0.69 log units) below the measured one, outside the stated range (above it).
By their numbers in this assay, from the lowest: compound 2; then compounds 1, 3 and 4 (each within the scatter of the next, the first and the last beyond it).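

With 4-fluorobenzyl and 4-methylbenzyl on the bromo-bearing core, the two compounds cannot be told apart (a 1.5-fold higher number from compound 3 to compound 4 (0.19 log units; within the scatter)). With 4-methylbenzyl held, bromo in place of chloro on an aromatic carbon gives the large step (a 13-fold higher number from compound 2 to compound 4 (1.11 log units; beyond the scatter)), so the low value of compound 2 goes with the chloro, not with the methyl. Against the unsubstituted amide nitrogen, 4-methylbenzyl gives a modest step (a 2.6-fold higher number from compound 1 to compound 4 (0.41 log units; beyond the scatter)).

Still open, from the compounds shown here alone, is how 4-fluorobenzyl behaves with chloro on the core, and how an amine or a carboxylic acid on the benzyl group would read. No supporting data bear on why these steps arise.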